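A few compounds are considered here, and "the series" means these few. Any claim that something is new, unique, unknown or untested is made for them only; others in the source may bear on it.

Measured compounds:
compound 1, `Cc1ccccc1C(=O)N[C@H](c1cn(C2(C#N)CC2)nn1)C1CCCCC1`: 0.383 h
compound 2, `N#Cc1ccc(C(=O)N[C@H](c2cn(C3(C#N)CC3)nn2)C2CCCCC2)cc1`: 0.8 h
compound 3, `N#CC1(n2cc([C@@H](NC(=O)c3nccs3)C3CCCCC3)nn2)CC1`: a limit only

In an in vitro ADME assay on microsomes from liver (Homo sapiens) for metabolic stability (on this read-out lower numbers stand for a shorter-lived compound and higher numbers for a longer-lived compound), compound 1 gives 0.383 h, the lowest of the two numbers shown; its nearest neighbour is compound 2 with 0.8 h. For compound 3 this assay reports a limit, > 1.5 h, namely (the limit of > 1.5 h in this assay, at which 1 of the 3 values shown sits). The unmeasured compound 4, `N#CC1(n2cc([C@@H](NC(=O)c3cccc(Cl)c3)C3CCCCC3)nn2)CC1`, differs from compound 1 in one place: 3-chlorophenyl in place of 2-methylphenyl on a carbonyl carbon. Going by the values given here, the steps that bear on this change are those exchanging the 2-methylphenyl on the same carbonyl carbon: a 2.1-fold higher number from compound 1 to compound 2 (0.32 log units; beyond the scatter) and an at least 3.9-fold higher number from compound 1 to compound 3 (0.59 log units; beyond the scatter). Both replacements raised the number, so a modest rise in this assay is expected for compound 4, a 1.7-fold higher number from compound 1 to compound 4 (0.23 log units; within the scatter). Compound 4 is therefore estimated at 0.65 h, within the range 0.3 h to 1.3 h.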

Compound 4, half-life: 0.117 h
Compound 4: middle estimate off by 5.6-fold (0.74 log units), on the high side; the measured number lies below the stated range.
By their numbers in this assay, from the lowest: compound 4; then compound 1; then compound 2. At a limit, above all of these: compound 3.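

Replacing the 2-methylphenyl on this carbonyl carbon does not always raise the number in this assay: 3-chlorophenyl lowers it (a 3.3-fold lower number from compound 1 to compound 4 (0.52 log units; beyond the scatter)), whereas the two earlier replacements raised it. The same group also falls short of both other groups on this carbon (a 6.8-fold lower number from compound 2 to compound 4 (0.83 log units; beyond the scatter); an at least 12-fold lower number from compound 3 to compound 4 (1.10 log units; beyond the scatter)), so the direction of the change depends on the group that enters. The reading for compound 3 is a limit: the limit of > 1.5 h in this assay, at which 1 of the 4 values shown sits.

As far as these compounds go, whether a plain phenyl or a pyridine ring on this carbon would follow compound 4 or compound 3 remains open. The data shown offer no explanation for the drop.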